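This account rests on a few compounds, and the source may have more. Where it says the series, first, only, none or still open, it means among the compounds named here.

Measured so far:
- compound 1, `O=C(NO)[C@H]1CCCCN1S(=O)(=O)N1CC=C(c2ccc(F)cc2)CC1`: 300 nM
- compound 2, `O=C(NO)[C@H]1CCCCN1S(=O)(=O)N1CC=C(c2ccc(Br)cc2)CC1`: 1200 nM
- compound 3, `COc1cccc(C2=CCN(S(=O)(=O)N3CCCC[C@@H]3C(=O)NO)CC2)c1`: 260 nM

All three numbers come from a functional assay on MONO-MAC-6 cells (Homo sapiens) for inhibition; on this read-out higher numbers stand for weaker inhibition and lower numbers for stronger inhibition. Compound 3 sits at the low end of the set: against compound 1 the gap is a 1.2-fold lower number from compound 1 to compound 3 (0.06 log units; within the scatter), which says nothing about order, while against compound 2 the gap is a 4.6-fold lower number from compound 2 to compound 3 (0.66 log units; beyond the scatter). Among the measured compounds shown here, compound 2 itself is set apart from compound 1 by a 4.0-fold higher number from compound 1 to compound 2 (0.60 log units; beyond the scatter), the only change among the measured compounds that moved the number outside the scatter.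

Compound 4, `O=C(NO)[C@H]1CCCCN1S(=O)(=O)N1CC=C(c2ccc(F)c(F)c2)CC1`, is reached from compound 3 by the change (3,4-difluorophenyl in place of 3-methoxyphenyl on a double-bonded ring carbon).

For the measured compounds named here, of the measured steps, the one from compound 1 to compound 3 bears most directly, since compound 1 already carries a fluoro-substituted ring and its number lies within the scatter of compound 3. The step from compound 2 to compound 3 shows that a bromo ring is worse than the methoxy ring, but nothing among these compounds says the same of a fluoro ring. A second fluorine is a small addition to what compound 1 carries, so no step beyond the scatter is expected in this assay. Compound 4 is therefore estimated at 330 nM, in the range 130 nM to 900 nM, a step of a 1.3-fold higher number from compound 3 to compound 4 (0.10 log units; within the scatter) that is expected to stay within the scatter.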

Compound 4, half-maximal inhibitory concentration: 1200 nM
Beside the measured number, compound 4's estimate is 3.6-fold (0.56 log units) below it; measured number outside the range, above it.
By their numbers in this assay, from the lowest: compounds 3 and 1 (each within the scatter of the next); then compounds 2 and 4 (each within the scatter of the next).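

Fluoro in place of hydrogen on an aromatic carbon is enough to give a 4.0-fold higher number from compound 1 to compound 4 (0.60 log units; beyond the scatter) in this assay, so at this position, three ring bonds from the ring nitrogen, one added fluorine can matter as much as the bromo-for-fluoro change did. The 3,4-difluorophenyl group gives a 4.6-fold higher number from compound 3 to compound 4 (0.66 log units; beyond the scatter), while against the 4-bromophenyl group it gives no change at the digits printed from compound 2 to compound 4 (within the scatter); the four compounds thus fall into two levels, compound 3 with compound 1 and compound 2 with compound 4. Halogen on the aromatic ring does not by itself mark the weaker level, as compound 1 goes against that reading, and nothing measured here explains the split between the levels.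

Open, going by these compounds, is how the unsubstituted phenyl group would sit against these two levels, and whether chlorophenyl or cyanophenyl groups would fall with compound 1 or with compound 2. Also open, on these data alone, is whether a pyridyl ring or an aminophenyl group at this carbon would go below the lower level, or whether the numbers seen here mark the range for this position.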